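The compounds below may be only part of what the source reports. "The series", "measured", "known", "first", "only" and "open" are said of these compounds alone.

Compound 1 `COc1ccc(/C=C/c2cc(=O)cco2)cc1`: 328 uM; compound 2 `COc1ccc(/C=C/c2cc(=O)cco2)cc1OC`: 540 uM; compound 3 `COc1ccc(/C=C/C2CC=CC(=O)O2)cc1`: 61.5 uM; all in a functional assay on OVCAR-3 cells (Homo sapiens) for inhibition, read by sulforhodamine B assay, with a stated time of 48 h; on this read-out lower numbers stand for stronger inhibition of growth and higher numbers for weaker inhibition of growth.

Compound 2 differs from compound 1 by methoxy in place of hydrogen on an aromatic carbon, and the step of a 1.6-fold higher number from compound 1 to compound 2 (0.22 log units; within the scatter). Compound 3 has a different core; how the two cores differ is not broken down here. Compound 4 `COc1ccc(/C=C/C2CC=CC(=O)O2)c(OC)c1` is not yet measured; it differs from compound 3 by methoxy in place of hydrogen on an aromatic carbon. This is the same kind of change as that from compound 1 to compound 2, though the surroundings differ: the new methoxy now sits ortho to a group of 9 heavy atoms and meta to a methoxy group, whereas before it sat ortho to a methoxy group and meta to a group of 9 heavy atoms. Because the earlier step of a 1.6-fold higher number from compound 1 to compound 2 (0.22 log units; within the scatter), a similarly small step is expected here, a 1.4-fold higher number from compound 3 to compound 4 (0.14 log units; within the scatter), resting on compound 3 at 61.5 uM. Compound 4 is therefore estimated at 85 uM, between 35 uM and 200 uM in this assay.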

Compound 4, concentration for growth inhibition (reported as GI): 5.6 uM
Compound 4: middle estimate off by 15-fold (1.18 log units), on the high side; measured number below the stated range.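

Putting a methoxy in place of a hydrogen on the aromatic ring has a large effect in this assay, with an 11-fold lower number from compound 3 to compound 4 (1.04 log units; beyond the scatter). The size of this step therefore does not carry over from one core to the other: the same change on two cores in this assay, a 1.6-fold higher number (0.22 log units; within the scatter) from compound 1 to compound 2 and an 11-fold lower number (1.04 log units; beyond the scatter) from compound 3 to compound 4, 18-fold (1.26 log units) apart, beyond the scatter of two such steps. This does not prove that the core alone sets the size of the step: the new methoxy sits ortho to a methoxy group in compound 2 but ortho to the group of 9 heavy atoms in compound 4, and two steps make no rule for the series.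

The compounds shown leave open whether the stronger growth inhibition of compound 4 belongs to methoxy in particular or would also come with a hydroxyl, a chlorine or a longer ethoxy chain on that carbon. They also leave open how the core of compound 3 would respond to a methoxy ortho to the existing methoxy group.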